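This account rests on a few compounds, and the source may have more. Where it says the series, first, only, none or still open, it means among the compounds named here.

Measured compounds:
compound 1, `O=C(O)CCc1ccc(NCc2ccccc2)cc1`, 144%
compound 2, `CN(C)Cc1ccc(CNc2ccc(CCC(=O)O)cc2)cc1`, 12%

In a functional assay on CHO cells for agonist activity at Free fatty acid receptor 1 (Homo sapiens), read by reporter gene assay (on this read-out lower numbers stand for smaller maximal responses and higher numbers for larger maximal responses), compound 2 stands lowest of the two numbers. Compound 1 gives 144%. For the measured compounds named here, the single measured step runs a number 132 percentage points lower from compound 1 to compound 2 (beyond the scatter). Compound 3, `O=C(O)CCc1ccc(NCc2ccc(C(=O)O)cc2)cc1`, differs from compound 2 by carboxy in place of (dimethylamino)methyl on an aromatic carbon. Going by the values given here, only that one step bears on this change: it shows that a group placed on this aromatic carbon, in place of hydrogen, can cut the maximal response deeply, but whether carboxy behaves like (dimethylamino)methyl is unknown. Compound 3 is therefore expected to rise, with a number 48 percentage points higher from compound 2 to compound 3 (beyond the scatter). The estimate for compound 3 is 60%, ranging from 10% to 140%.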

Compound 3, largest response reached (reported as percent of maximum), in percent of the reference or control that the assay uses: 9%
For compound 3 the middle estimate is 51 percentage points above the measured one; the whole stated range lies above it.
By their numbers in this assay, from the lowest: compounds 3 and 2 (each within the scatter of the next); then compound 1.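

In this assay, the loss seen with (dimethylamino)methyl on this aromatic carbon is not unique to that group: carboxy in place of hydrogen gives a number 135 percentage points lower from compound 1 to compound 3 (beyond the scatter). The two groups cannot be told apart here, with a number 3 percentage points lower from compound 2 to compound 3 (within the scatter), so a deep loss of maximal response appears with both an amine and a carboxylic acid at this position. No available evidence explains this loss. Going by these compounds, it remains open whether a methyl group or a chlorine atom on this carbon would keep the response of compound 1, and whether an ester or amide would behave like carboxy.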